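Compound 3 to compound 4: an aromatic group enters

The source may hold more compounds than are shown below. What is called first, only, known or untested is meant among the compounds shown, and "the series" means these compounds.

compound 1 `CCc1ccc(N(CC(C)C)S(=O)(=O)c2ccc3c(c2)C(=O)CC(CC2CCOCC2)O3)cc1`: 4.53
compound 2 `CC(C)CN(c1ccc(F)cc1F)S(=O)(=O)c1ccc2c(c1)C(=O)CC(C1CCOCC1)O2`: 3.62
compound 3 `CCc1ccc(N(CC(C)C)S(=O)(=O)c2ccc3c(c2)C(=O)CC(C2(C)CCOCC2)O3)cc1`: 4.71

All three values come from a physicochemical assay for lipophilicity, at pH 7.4; a lower number here means a more polar compound, a higher number a more lipophilic compound. Compound 3, at 4.71, lies within the scatter of compound 1, at 4.53. Compound 2, at 3.62, stands lower than both, beyond the scatter. Going by the values given here, compound 2 differs from compound 3 in more than one place, so it offers no clean step here.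

The next structure is compound 4 `CCc1ccc(N(CC(C)C)S(=O)(=O)c2ccc3c(c2)C(=O)CC(c2c(C)noc2C)O3)cc1`. It carries 3,5-dimethyl-1,2-oxazol-4-yl in place of 4-methyloxan-4-yl on a saturated ring carbon, next to the ring oxygen: 3,5-dimethyl-1,2-oxazol-4-yl in place of 4-methyloxan-4-yl on a saturated ring carbon.

Among the compounds with values here, only one measured step touches this place: a number 0.18 log units higher from compound 1 to compound 3 (within the scatter). That step exchanges one saturated oxane-bearing group for another and stays within the scatter. Within the data shown here, it therefore bears only partly on the new change, as no measured step brings a five-membered aromatic ring to this carbon. With that gap in the data, no step beyond the scatter is expected in this assay, with only a weak lean to a lower number. The expected move is a number 0.21 log units lower from compound 3 to compound 4 (within the scatter). For compound 4 the estimated value is 4.5, with an expected range of 4.1 to 4.9.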

Compound 4, distribution coefficient: 4.42
Compound 4: the middle estimate sits 0.08 log units above what was measured; measured number inside the range.
By their numbers in this assay, from the lowest: compound 2; then compounds 4, 1 and 3 (each within the scatter of the next).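

In this assay, going by these compounds alone, placing 3,5-dimethyl-1,2-oxazol-4-yl in place of 4-methyloxan-4-yl on the saturated ring carbon gives a number 0.29 log units lower from compound 3 to compound 4 (within the scatter), the first reading for an aromatic group at this place. Set against the group with the extra carbon between ring and core, the same five-membered aromatic ring gives (a number 0.11 log units lower from compound 1 to compound 4 (within the scatter)), so at this place, within these three compounds, one six-membered non-aromatic ring with 1 hetero atom and one five-membered aromatic ring with 2 hetero atoms cannot be told apart in this read-out, although the hydrogen-bond acceptor count goes from 1 to 2. No supporting measurement bears on why these numbers stay together, so the result stands as an observation only.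

Open is whether any group on this saturated ring carbon can move the read-out beyond the scatter, for instance an amine or a carboxylic acid, since all the groups shown there carry no net charge. Compound 2 differs from the other compounds in more than one place, so its steps to them cannot be read, and the part played by its aryl group on the sulfonamide nitrogen stays separate from anything seen at this carbon.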